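Aryl versus aryloxy at the fused core: cytotoxicity notes

The source may hold more compounds than are shown below. What is called first, only, known or untested is meant among the compounds shown, and "the series" means these compounds.

Measured in an ADME assay on HepG2 cells (Homo sapiens) for cytotoxicity, read by luminescence, CellTiter-Glo and ATP content, with a stated time of 72 h; on this read-out higher numbers stand for an effect only at larger amounts of compound and lower numbers for an effect already at smaller amounts:
- compound 1 `COc1cccc(Oc2ccc3c(NCCCNCc4cc(F)ccc4OC)ccnc3c2)c1`: 7100 nM
- compound 2 `Fc1ccc(Oc2ccc3c(NCCCNCc4ccco4)ccnc3c2)cc1`: 16000 nM
- compound 3 `COc1ccc(-c2ccc3c(NCCCNCc4ccco4)ccnc3c2)cc1`: 6000 nM

Compound 3 gives the lowest of the three numbers in this assay. Its gap to compound 1 lies within the scatter; its gap to compound 2 lies beyond it, as the step of a 2.7-fold lower number from compound 2 to compound 3 (0.43 log units; beyond the scatter) shows, where 4-methoxyphenyl replaced 4-fluorophenoxy.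

Compound 4 `COc1cccc(Oc2ccc3c(NCCCNCc4ccco4)ccnc3c2)c1` is not yet measured. It differs from compound 3 as follows:
3-methoxyphenoxy in place of 4-methoxyphenyl on an aromatic carbon

Within the data shown here, the only step on the same position is a 2.7-fold lower number from compound 2 to compound 3 (0.43 log units; beyond the scatter), a modest step in which an aryloxy group gave way to an aryl group; the present change runs the other way, aryl to aryloxy. Compound 1 also carries 3-methoxyphenoxy, and its value sits within the scatter of compound 3. Taken together, a small rise is expected, a 1.5-fold higher number from compound 3 to compound 4 (0.18 log units; within the scatter), with the outcome possibly within the scatter. Compound 4 is therefore estimated at 9000 nM in this assay, in a range from 4500 nM to 18000 nM.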

Compound 4, half-maximal effective concentration: 15500 nM
Compound 4: the middle estimate sits 1.7-fold (0.24 log units) below what was measured; the range from low to high includes it.
By their numbers in this assay, from the lowest: compounds 3 and 1 (each within the scatter of the next); then compounds 4 and 2 (each within the scatter of the next).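

In this assay, the change at this position now reads in both directions: a 2.6-fold higher number from compound 3 to compound 4 (0.41 log units; beyond the scatter) mirrors a 2.7-fold lower number from compound 2 to compound 3 (0.43 log units; beyond the scatter), and in both steps the aryl compound gives the lower number. Changing the ring on the oxygen leaves the number within the scatter, with a 1.0-fold lower number from compound 2 to compound 4 (0.01 log units; within the scatter), so among these two aryloxy compounds 3-methoxyphenyl and 4-fluorophenyl do not separate. With 3-methoxyphenoxy held constant, the other end of the molecule also moves the number, as a 2.2-fold higher number from compound 1 to compound 4 (0.34 log units; beyond the scatter) shows for furan-2-yl in place of 5-fluoro-2-methoxyphenyl.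

Nothing at hand accounts for these steps. Still open, as far as these compounds go, is whether the aryl and aryloxy compounds stay apart when the ring carries the same substituent at the same place, for example with the group 3-methoxyphenyl joined directly to the core, and whether an amine or a carboxylic acid on that ring would shift the number.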